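The source may report more compounds than this note shows. Statements on the series, on what has been measured and on what is new or still open speak of the compounds shown alone.

Of the compounds shown here, three built on one shared core have been tested in an assay for activation of interferon regulatory factor 3 (Homo sapiens), read by a luciferase reporter, with a stated time of 20 h; a lower number here means that less compound is needed, a higher number that more compound is needed for the effect. Compound 1 `CCn1nc(C)cc1C(=O)Nc1nc2cc(C(N)=O)cc(OC)c2n1CCCNC(=O)OCc1ccccc1` gives in this assay only a limit, > 100000 nM. Compound 2 `COc1cc(C(N)=O)cc2nc(NC(=O)c3ccnn3C)n(CCCNC(=O)OCc3ccccc3)c12` likewise gives in this assay only a limit, > 100000 nM. Compound 3 `COc1cc(C(N)=O)cc2nc(NC(=O)c3cccn3C)n(CCCNC(=O)OCc3ccccc3)c12` also gives in this assay only a limit, > 100000 nM. The three steps between these compounds, a step that the two limits leave unreadable from compound 1 to compound 2, a step that the two limits leave unreadable from compound 1 to compound 3 and a step that the two limits leave unreadable from compound 2 to compound 3, cannot be read in size or direction because of the limit of > 100000 nM in this assay, at which 3 of the 3 values shown sit.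

Compound 4 `COc1cc(C(N)=O)cc2nc(NC(=O)C3CCN(C)CC3)n(CCCNC(=O)OCc3ccccc3)c12` has not yet been measured. It differs from compound 3 in one place: 1-methylpiperidin-4-yl in place of 1-methyl-1H-pyrrol-2-yl on a carbonyl carbon. Among the compounds with values here, none of the three measured steps carries a readable size, so they offer no direction for this change, and there is nothing among the measured compounds that points to a gain. Compound 4 is therefore expected to sit around 100000 nM, within a range from 30000 nM to 300000 nM, most likely again as a limit. Put as a step, this expectation reads a number no higher from compound 3 to compound 4 (the limit leaves the size open).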

Compound 4, half-maximal effective concentration: > 100000 nM
Compound 4: a limit, no number; the forecaster's own chance of this, stated with the estimate: 80%; the middle value lies on the limit itself.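

Compound 4 also gives only a limit, so its steps to compound 1, compound 2 and compound 3 cannot be read in size or direction, because all four results stop at the same point: the limit of > 100000 nM in this assay, at which 4 of the 4 values shown sit.

The compounds shown leave open which group on the carbonyl carbon, if any, would give a measurable value in this assay.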